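2-Phenylethenyl in Place of Furan-2-yl on the Carbonyl

This account rests on a few compounds, and the source may have more. Where it says the series, first, only, none or still open, it means among the compounds named here.

Compound 1 `CCCCCCCCNC(=O)[C@@H](NC(=O)c1ccco1)[C@@H](C)O` stands highest of the two measured compounds in a functional assay on HepG2 cells (Homo sapiens) for cytotoxicity, read by MTT assay, with a stated time of 48 h (a higher number here means a weaker inhibitor, a lower number a stronger inhibitor), where compound 1 gives 192000 nM. Compound 2 `CCCCCCCCNC(=O)[C@@H](NC(=O)c1nccc2ccccc12)[C@@H](C)O` gives 88200 nM, a lower number that lies beyond the usual scatter. Going by the values given here, compound 3 `CCCCCCCCNC(=O)[C@@H](NC(=O)/C=C/c1ccccc1)[C@@H](C)O` differs from compound 1 by 2-phenylethenyl in place of furan-2-yl on a carbonyl carbon, a change for which no measured pair exists. The step is expected to be small and downward, a 1.6-fold lower number from compound 1 to compound 3 (0.20 log units; within the scatter), though it may not clear the scatter. Compound 3 is therefore estimated at 120000 nM, within a range from 50000 nM to 300000 nM.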

Compound 3, half-maximal inhibitory concentration: 55600 nM
Estimate against measurement, compound 3: 2.2-fold (0.33 log units) above, and the stated range covers the measured number.
By their numbers in this assay, from the lowest: compounds 3 and 2 (each within the scatter of the next); then compound 1.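

In this assay, going by these compounds alone, the change from furan-2-yl to 2-phenylethenyl on the carbonyl carbon gives a 3.5-fold lower number from compound 1 to compound 3 (0.54 log units; beyond the scatter) and is the first step at this position read between measured compounds. It shows that the group on this carbonyl can move the number beyond the scatter, here with one six-membered aromatic ring of carbon only and one double bond outside aromatic rings entering. Nothing measured here explains the step. The compounds shown leave open whether 2-phenylethyl, with the double bond saturated, or phenyl directly on the carbonyl would give a similar number.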